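This account rests on a few compounds, and the source may have more. Where it says the series, first, only, none or still open, it means among the compounds named here.

The study reports three compounds in a functional assay on PC-3 cells (Homo sapiens) for cytotoxicity, read by WST assay, with a stated time of 48 h; on this read-out higher numbers stand for weaker inhibition and lower numbers for stronger inhibition. Compound 2 `COc1ccc(Cn2cc(/C=C(\C#N)C(=O)c3c[nH]c4cc(OC)ccc34)c3ccccc32)cc1` gives in this assay only a limit of the assay, > 50000 nM, and no number. Compound 1 `N#C/C(=C\c1cn(Cc2ccc(Cl)cc2)c2ccccc12)C(=O)c1c[nH]c2ccccc12` likewise reaches in this assay only the limit > 50000 nM. Within the data shown here, compound 3 `COc1ccc2c(/C=C(\C#N)C(=O)c3c[nH]c4cc(OC)ccc34)c[nH]c2c1` is the single compound that returns a number in this assay, 27000 nM. Compound 2 therefore stands at the edge of what this assay can read, a position it shares with one further value (the limit of > 50000 nM in this assay, at which 2 of the 3 values shown sit); the numbers shown do not place compound 2 above or below compound 1.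

The unmeasured compound 4 `COc1ccc2c(C(=O)/C(C#N)=C/c3cn(Cc4ccc(Cl)cc4)c4ccccc34)c[nH]c2c1` differs from compound 2 in one place: chloro in place of methoxy on an aromatic carbon. Among the measured compounds shown here, no measured pair of compounds isolates this change, so no measured step can be quoted for it. Both compound 1 and compound 2, which between them carry the 4-chlorobenzyl and the 4-methoxybenzyl group, sit at the limit of this assay, and nothing among the shown values suggests that the change frees compound 4 from that limit. The step from compound 2 to compound 4 is therefore expected to be a step that the limit leaves unreadable from compound 2 to compound 4, none beyond the scatter. Compound 4 is estimated at 60000 nM in this assay, within 30000 nM to 150000 nM, and most likely it too will be reported only as a limit.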

Compound 4, half-maximal inhibitory concentration: > 50000 nM
Compound 4: no number, only a limit; the forecaster's own chance of this, stated with the estimate: 75%; the middle value is on the limit's open side.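

In this assay compound 4 gives only a limit, > 50000 nM. No step from compound 2 or compound 1 to compound 4 can be read, as all three compounds stop at a limit: the limit of > 50000 nM in this assay, at which 3 of the 4 values shown sit.

The compounds shown leave open whether chloro in place of methoxy, or methoxy in place of hydrogen, changes anything in this assay.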